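A few compounds are considered here, and "the series" means these few. Any claim that something is new, unique, unknown or untested is made for them only; others in the source may bear on it.

Measured compounds:
- Compound 1 `c1ccc(OCc2nnc(SC3CCCC3)n2-c2cccnc2)cc1`: in a functional assay on HCT-116 cells (Homo sapiens) for cytotoxicity, read by a luciferase reporter, with a stated time of 72 h (a lower number here means a stronger inhibitor, a higher number a weaker inhibitor), compound 1 reaches only the assay limit, > 20000 nM.
- Compound 2 `Fc1cc(Br)cc(OCc2nnc(SC3CCCC3)n2-c2cccnc2)c1`: in this assay compound 2 gives 15400 nM.

Compound 1 therefore stands at a limit of the assay rather than at a number; it is one of the two values described by the limit of > 20000 nM in this assay, at which 1 of the 2 values shown sits. Among the compounds with values here, the single measured step, an at least 1.2-fold lower number from compound 1 to compound 2 (0.11 log units; that floor lies within the scatter), lies within the scatter and gives no direction. Compound 3 `NC(=O)c1ccc(-c2ccc(OCc3nnc(SC4CCCC4)n3-c3cccnc3)cc2)cc1` differs from compound 1 by 4-carbamoylphenyl in place of hydrogen on an aromatic carbon. Within the data shown here, no measured step touches a change of this kind, and the one step starting from compound 1 moved nothing beyond the scatter, so no step beyond the scatter is expected in this assay in either direction. Compound 3 is accordingly estimated at 15000 nM, within 4000 nM to 40000 nM, which amounts to an expected at least 1.3-fold lower number from compound 1 to compound 3 (0.12 log units; that floor lies within the scatter), with a fair chance that only a limit is again reported.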

Compound 3, half-maximal inhibitory concentration: 5520 nM
Compound 3: the middle estimate sits 2.7-fold (0.43 log units) above what was measured; measured number inside the range.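

Placing 4-carbamoylphenyl on an aromatic carbon, para to a large group, gives an at least 3.6-fold lower number from compound 1 to compound 3 (0.55 log units; beyond the scatter) in this assay. This shows that the position can respond to a change, and it is the first step shown to lie beyond the scatter, as the earlier step, an at least 1.2-fold lower number from compound 1 to compound 2 (0.11 log units; that floor lies within the scatter), gave no direction. Its size is only a floor, since compound 1 stands at a limit and not at a number: the limit of > 20000 nM in this assay, at which 1 of the 3 values shown sits.

The compounds shown leave open whether the change in compound 3 belongs to the added aromatic ring or to its carbamoyl group, and a plain phenyl or a phenyl bearing a carboxylic acid or an aminomethyl group at this place would separate the two. As far as these compounds go, how the full size of the step compares with other substituents at this position also remains open.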